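This account rests on a few compounds, and the source may have more. Where it says the series, first, only, none or still open, it means among the compounds named here.

Measured compounds:
Compound 1 `O=C1C(Nc2ccccc2)=CC(=O)c2c1nc1n2[C@H]2OC[C@@H](O)[C@H]2OC1` gives 3560 nM in a functional assay on ECa-109 cells for inhibition, with ECa-109 cell line (Homo sapiens) as the target, read by sulforhodamine B assay; a lower number here means a stronger inhibitor, a higher number a weaker inhibitor.
Compound 2 `O=C1C=C(Nc2cccc(F)c2)C(=O)c2c1nc1n2[C@H]2OC[C@@H](O)[C@H]2OC1` gives 7030 nM in this assay.
Compound 3 `O=C1C=C(Nc2ccc(C(F)(F)F)cc2)C(=O)c2c1nc1n2[C@H]2OC[C@@H](O)[C@H]2OC1` gives 5500 nM in this assay.

All three compounds share one core and differ only in the group on the amine nitrogen. Compound 1 has the lowest number of the three, but its distance to compound 3 and to compound 2 is within the usual scatter, so the three cannot be ranked with confidence.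

Compound 4 `O=C1C(Nc2cccc(Cl)c2)=CC(=O)c2c1nc1n2[C@H]2OC[C@@H](O)[C@H]2OC1` is the unmeasured compound. It differs from compound 1 as follows: chloro in place of hydrogen on an aromatic carbon.

Within the data shown here, the one measured step that bears on this, a 1.3-fold lower number from compound 2 to compound 3 (0.11 log units; within the scatter), shows that exchanging one substituted phenyl for another leaves the number within the scatter. The pair compound 1 and compound 2 shows only that adding a single fluorine to the phenyl moves the number by an amount that also stays within the scatter. Among the measured compounds shown here, a chlorine in the same position has no direct precedent here.

Taken together, the step of a 1.3-fold higher number from compound 1 to compound 4 (0.10 log units; within the scatter) is expected to stay within the scatter, possibly with a slightly higher number as seen for compound 2 with 7030 nM. Compound 4 is therefore estimated at 4500 nM, with a range from 2000 nM to 10000 nM.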

Compound 4, half-maximal inhibitory concentration: 3080 nM
Estimate against measurement, compound 4: 1.5-fold (0.16 log units) above, within the range that was stated.
By their numbers in this assay, from the lowest: compounds 4, 1, 3 and 2 (each within the scatter of the next, the first and the last beyond it).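

In this assay, chloro in place of hydrogen on the aromatic carbon meta to a large group gives a 1.2-fold lower number from compound 1 to compound 4 (0.06 log units; within the scatter), so this position of the phenyl ring can carry a chlorine without the number leaving the scatter. Among these compounds, the same position carries the fluorine of compound 2, and here the choice of halogen shows for the first time: the 3-fluorophenyl of compound 2 at 7030 nM and the 3-chlorophenyl of compound 4 at 3080 nM lie beyond the scatter of each other, although each stays within the scatter of compound 1. Nothing measured here gives a reason for this gap between the two halogens.

Going by these compounds, it remains open whether a different kind of group at this position, such as a methoxy group, an amine or a carboxylic acid, would also stay within the scatter, and what chloro would do on the other carbons of the ring. On these data alone, all four compounds share one core and vary only in the aryl group on the amine nitrogen, so the effect of changes anywhere else on the core also remains open.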